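The source may hold more compounds than are shown below. What is called first, only, known or untested is meant among the compounds shown, and "the series" means these compounds.

Three compounds sharing one core have gone into a functional assay on SK-BR-3 cells (Homo sapiens) for cytotoxicity, read by MTT assay, with a stated time of 72 h (on this read-out higher numbers stand for weaker inhibition and lower numbers for stronger inhibition), yet only one of them carries a number. Compound 1 `N[C@H]1CC[C@H](Nc2c(C(=O)NCc3ccc(Oc4ccccc4)cc3)nc(Br)c3cccnc23)CC1` is recorded as "not determined" (no result reported). Compound 2 `CN(C)c1ccc(CNC(=O)c2nc(Br)c3cccnc3c2N[C@H]2CC[C@H](N)CC2)cc1` is recorded as "not determined" (no result reported), so it has no single number to stand on, and compound 1 offers none either. Compound 3 `O=C(NCc1ccc(F)cc1)c1nc(Br)c2cccnc2c1N1CCNCC1` gives 6000 nM.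

Compound 4 `N[C@H]1CC[C@H](Nc2c(C(=O)NC3CCCCC3)nc(Br)c3cccnc23)CC1` has still to be measured in this assay. It departs from compound 2 by one change, cyclohexyl in place of 4-(dimethylamino)benzyl on an amide-type nitrogen. Among the measured compounds shown here, no measured pair shows what such a change does, and without a number for compound 2 no step from it can be read. For the measured compounds named here, the only anchor is compound 3 at 6000 nM, so no step beyond the scatter, in either direction, is expected from that value in this assay. This rests on thin evidence, and the range is kept wide. Compound 4 is estimated at 5000 nM, with an expected range from 1200 nM to 20000 nM.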

Compound 4, half-maximal inhibitory concentration: 4200 nM
The estimate for compound 4 lay 1.2-fold (0.08 log units) above the measured number; low and high end bracket the measured number.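

Among the compounds shown here, compound 2 has no single number in this assay, so no step to compound 4 can be read, and neither can any effect of cyclohexyl replacing 4-(dimethylamino)benzyl. The compounds shown leave open how the group on the amide-type nitrogen alters cytotoxicity. No supporting evidence bears on this result.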